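Replacing the Methoxyphenyl Ketone Arm with Difluorophenyl

A few compounds are considered here, and "the series" means these few. Any claim that something is new, unique, unknown or untested is made for them only; others in the source may bear on it.

Of the compounds shown here, two of a shared core have so far been measured in a functional assay on NCI/ADR-RES cells (Homo sapiens) for inhibition, read by sulforhodamine B assay, with a stated time of 48 h; on this read-out higher numbers stand for weaker inhibition of growth and lower numbers for stronger inhibition of growth. Compound 1 `COc1ccc(C(=O)/C=C/c2cc(-c3cc(OC)c(OC)c(OC)c3)n[nH]2)cc1OC` gives 3130 nM, and compound 2 `COc1ccc(C(=O)/C=C/c2cc(-c3cc(OC)c(OC)c(OC)c3)n[nH]2)cc1` gives 2700 nM. For the measured compounds named here, the single step between them, a 1.2-fold lower number from compound 1 to compound 2 (0.06 log units; within the scatter), exchanged a methoxy on an aromatic carbon for hydrogen and moved the number by less than the scatter. Going by the values given here, compound 2 thus holds the lowest of the two numbers, with compound 1 as its only neighbour and within the scatter of it, so no order between the two can be claimed.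

Compound 3 `COc1cc(-c2cc(/C=C/C(=O)c3ccc(F)c(F)c3)[nH]n2)cc(OC)c1OC` is not yet measured. It differs from compound 2 in one place: 3,4-difluorophenyl in place of 4-methoxyphenyl on a carbonyl carbon. Among the compounds with values here, no measured step touches the aryl group on the carbonyl carbon; the one step known concerns a different ring and stayed within the scatter, so it offers no ground for expecting a shift beyond the scatter in this assay. Compound 3 is therefore estimated to give about 2500 nM in this assay, with a plausible range from 800 nM to 8000 nM. This expectation corresponds to a 1.1-fold lower number from compound 2 to compound 3 (0.03 log units; within the scatter).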

Compound 3, concentration for 50% growth inhibition: 3460 nM
Compound 3: middle estimate off by 1.4-fold (0.14 log units), on the low side; low and high end bracket the measured number.
By their numbers in this assay, from the lowest: compounds 2, 1 and 3 (each within the scatter of the next).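

With 3,4-difluorophenyl in place of 4-methoxyphenyl on a carbonyl carbon, this assay shows a 1.3-fold higher number from compound 2 to compound 3 (0.11 log units; within the scatter), and with the same group in place of 3,4-dimethoxyphenyl it shows a 1.1-fold higher number from compound 1 to compound 3 (0.04 log units; within the scatter). The earlier compounds shown here had varied only the number of methoxy groups on this aryl group, whereas compound 3 carries none and has two fluorines instead, and it still cannot be told apart from compound 1 or compound 2 on this read-out. Nothing available bears on why these numbers lie so close together.

On these data alone, all three groups on the carbonyl carbon are six-membered aromatic rings of carbon only, so it remains open whether this insensitivity would hold for a saturated ring such as cyclohexyl, or for a phenyl ring carrying an amine or a carboxylic acid. The compounds also leave open how the number would respond to changes elsewhere on the shared core, such as replacing the methoxy groups of the other aryl ring with hydroxyl groups.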